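The compounds below may be only part of what the source reports. "The series", "measured", "known", "first", "only" and "open" are said of these compounds alone.

In an ADME assay on L02 cells (Homo sapiens) for cytotoxicity, read by MTT assay, with a stated time of 24 h (a higher number here means a weaker inhibitor, a lower number a stronger inhibitor), compound 1 `CN1C/C(=C\c2ccncc2)C(=O)/C(=C/c2ccccc2C(F)(F)F)C1` gives 15800 nM and compound 2 `Cc1ccc(S(=O)(=O)N2C/C(=C\c3ccncc3)C(=O)/C(=C/c3ccccc3C(F)(F)F)C2)cc1` gives 12800 nM. Compound 2 therefore cannot be separated from compound 1 on these numbers. Compound 3 `O=C1/C(=C/c2ccncc2)CN(S(=O)(=O)c2ccc([N+](=O)[O-])cc2)C/C1=C\c1ccccc1C(F)(F)F` keeps the rest of compound 2 and makes one small swap: nitro in place of methyl on an aromatic carbon, para to a large group, which turns (4-methylphenyl)sulfonyl into (4-nitrophenyl)sulfonyl (nitro in place of methyl on an aromatic carbon). Going by the values given here, no measured pair tests this swap directly. The nearest evidence is a different change on the amine nitrogen in a ring, a 1.2-fold lower number from compound 1 to compound 2 (0.09 log units; within the scatter), where replacing methyl with the whole (4-methylphenyl)sulfonyl group moved this assay by no more than the scatter. On that thin basis, no step beyond the scatter is expected, and the estimated step is a 1.2-fold lower number from compound 2 to compound 3 (0.07 log units; within the scatter). For compound 3, the expected value is about 11000 nM, within an estimated range of 5000 nM to 22000 nM.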

Compound 3, half-maximal inhibitory concentration: 18600 nM
Compound 3: middle estimate off by 1.7-fold (0.23 log units), on the low side, within the range that was stated.
By their numbers in this assay, from the lowest: compounds 2, 1 and 3 (each within the scatter of the next).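

Read directly for the first time, nitro in place of methyl on this aromatic carbon, para to a large group, gives a 1.5-fold higher number from compound 2 to compound 3 (0.16 log units; within the scatter) in this assay, even though three heavy atoms and two hydrogen-bond acceptors enter where one carbon leaves. Setting the whole (4-nitrophenyl)sulfonyl group in place of methyl on the ring amine nitrogen gives a 1.2-fold higher number from compound 1 to compound 3 (0.07 log units; within the scatter) and likewise stays inside the scatter, so neither swap separates these compounds in this assay. No independent measurement here offers an explanation for these small steps. Still open, from the compounds shown here alone, is whether an amine or a carboxylic acid on this aromatic carbon would move the number beyond the scatter. Also open, going by these compounds, is whether a longer chain on the ring nitrogen would do so.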